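Swapping the Aryl Urea Cap for an Acetoxythiophene

A few compounds are considered here, and "the series" means these few. Any claim that something is new, unique, unknown or untested is made for them only; others in the source may bear on it.

Among the measured compounds shown here, in a functional assay on A549 cells (Homo sapiens) for inhibition, read by MTT assay and WST assay, with a stated time of 72 h, tested at 10 uM (a lower number here means less inhibition of growth, a higher number more inhibition of growth at the concentration tested), compound 2 `Cc1ccc(NC(=O)Nc2ccc(Oc3ccc(-c4ncc[nH]4)cc3)cc2)cc1` gives 24.6%, the higher of the two numbers measured so far; compound 1 `O=C(Nc1ccc(Cl)cc1)Nc1ccc(Oc2ccc(-c3ncc[nH]3)cc2)cc1` gives 8.86%. For the measured compounds named here, the only measured step, a number 15.7 percentage points higher from compound 1 to compound 2 (beyond the scatter), exchanges one small group for another on an aromatic carbon. Compound 3 `CC(=O)Oc1sccc1NC(=O)Nc1ccc(Oc2ccc(-c3ncc[nH]3)cc2)cc1` carries a larger change: 2-acetoxythiophen-3-yl in place of 4-methylphenyl on an amide-type nitrogen. Going by the values given here, no measured step covers an exchange of the whole ring, so the direction is open, and a modest step either way or none beyond the scatter is possible. Compound 3 is expected to give 20%, between 5% and 40%, a step of a number 4.6 percentage points lower from compound 2 to compound 3 (within the scatter).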

Compound 3, percent growth inhibition at one concentration: 2.34%
The estimate for compound 3 lay 17.7 percentage points above the measured number; the whole stated range lies above it.
By their numbers in this assay, from the lowest: compounds 3 and 1 (each within the scatter of the next); then compound 2.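

The 2-acetoxythiophen-3-yl group in place of 4-methylphenyl on this amide-type nitrogen lowers growth inhibition in this assay (a number 22.3 percentage points lower from compound 2 to compound 3 (beyond the scatter)), so exchanging the whole ring here can change the reading. In place of 4-chlorophenyl, the same group stays within the scatter (a number 6.5 percentage points lower from compound 1 to compound 3 (within the scatter)), so the result depends on which ring it replaces. Nothing measured here explains this difference. The compounds shown do not separate the acetoxy group from the thiophene ring. As far as these compounds go, how a plain thiophen-3-yl or an aromatic ring bearing an amine would read at this nitrogen remains open.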